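This account rests on a few compounds, and the source may have more. Where it says the series, first, only, none or still open, it means among the compounds named here.

Working notes on the series.

Three members have been measured in a functional assay on HeLa cells (Homo sapiens) for inhibition, read by MTT assay, with a stated time of 24 h; a higher number here means a weaker inhibitor, a lower number a stronger inhibitor. Compound 1 `O=C(O)C1=Cc2ccccc2OC1(OCc1cc(-c2ccc(F)cc2)no1)C(F)(F)F` carries a free carboxylic acid and a 4-fluorophenyl group; in this assay compound 1 reports only a limit, > 150000 nM. Compound 3 `O=C(O)C1=Cc2ccccc2OC1(OCc1cc(-c2cccc(C(F)(F)F)c2)no1)C(F)(F)F` keeps the acid but bears a 3-(trifluoromethyl)phenyl group; in this assay compound 3 likewise reports only a limit, > 150000 nM. Going by the values given here, compound 2 `CCOC(=O)C1=Cc2ccccc2OC1(OCc1cc(-c2cccc(C(F)(F)F)c2)no1)C(F)(F)F` is the ethyl ester of compound 3, and in this assay compound 2 gives 21400 nM, the only number so far.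

The two cores differ by ethyl in place of hydrogen on an oxygen next to a carbonyl group. Going the other way, the ester-to-acid step is an at least 7.0-fold higher number from compound 2 to compound 3 (0.84 log units; beyond the scatter).

The aryl swap has been made once between measured compounds, as 4-fluorophenyl in place of 3-(trifluoromethyl)phenyl on an aromatic carbon, and the step is a step that the two limits leave unreadable from compound 3 to compound 1, which rests on the limit of > 150000 nM in this assay, at which 2 of the 3 values shown sit, and therefore tells nothing about the size of the change.

Compound 4 `CCOC(=O)C1=Cc2ccccc2OC1(OCc1cc(-c2ccc(F)cc2)no1)C(F)(F)F` is not yet measured. It differs from compound 2 by 4-fluorophenyl in place of 3-(trifluoromethyl)phenyl on an aromatic carbon; the surroundings of the change read the same as between compound 3 and compound 1, so this is the same change carried onto the ester core. No readable precedent exists for its size. With compound 2 at 21400 nM as the only anchor, the step is expected to be a 1.2-fold higher number from compound 2 to compound 4 (0.07 log units; within the scatter), taken as small in the absence of any measured pull either way. For compound 4 the expected value in this assay is therefore 25000 nM, with the estimate spanning 8000 nM to 80000 nM.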

Compound 4, half-maximal inhibitory concentration: 42300 nM
Compound 4: middle estimate off by 1.7-fold (0.23 log units), on the low side; the range from low to high includes it.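

On the ester core the swap of 3-(trifluoromethyl)phenyl for 4-fluorophenyl reads in this assay as a 2.0-fold higher number from compound 2 to compound 4 (0.30 log units; within the scatter), so compound 2 and compound 4 stand level, whereas the same swap on the acid core cannot be read, and no comparison of the swap between the two cores is possible: the limit of > 150000 nM in this assay, at which 2 of the 4 values shown sit.

The other change, ethyl in place of hydrogen on the oxygen next to the carbonyl group, can be followed on both aryl groups and appears as an at least 3.5-fold lower number from compound 1 to compound 4 (0.54 log units; beyond the scatter), pointing the same way as the step on the 3-(trifluoromethyl)phenyl pair, so in these four compounds each ethyl ester gives a lower number than its free acid. What this does not show is whether the change has the same size on the two cores, since each size is only a bound: the same change on two cores in this assay, an at least 7.0-fold higher number (0.84 log units; beyond the scatter) from compound 2 to compound 3 and an at least 3.5-fold higher number (0.54 log units; beyond the scatter) from compound 4 to compound 1; the limit leaves it open whether they differ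

The compounds shown leave open whether the ester's effect is specific to ethyl, as a methyl ester, a longer chain or an amide in that place would test. They also leave open how the series responds when the aryl group carries something other than fluorine or trifluoromethyl, such as a nitrile or an amine.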